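The compounds below may be only part of what the source reports. "The series", "measured", "known", "first", "only" and "open" are said of these compounds alone.

Compound 1 `COc1cccc(/C=C/C(=O)c2sc(Nc3cccc(C)c3)nc2C)c1`: > 25000 nM
Compound 2 `Cc1cccc(Nc2nc(C)c(C(=O)/C=C/c3ccccc3Cl)s2)c1`: > 25000 nM
Compound 3 `Cc1cccc(Nc2nc(C)c(C(=O)/C=C/c3ccccc3)s2)c1`: 21800 nM

In a functional assay on NCI-H460 cells (Homo sapiens) for cytotoxicity, read by MTT assay (a higher number here means a weaker inhibitor, a lower number a stronger inhibitor), compound 1 gives > 25000 nM, which is a limit of the assay and not a number. Compound 2 also reaches only a limit, > 25000 nM. Going by the values given here, compound 3, the one compound with a number, gives 21800 nM. The measured steps all concern the aryl group on the double-bonded chain carbon: an at least 1.1-fold lower number from compound 1 to compound 3 (0.05 log units; that floor lies within the scatter), an at least 1.1-fold lower number from compound 2 to compound 3 (0.05 log units; that floor lies within the scatter), and a step that the two limits leave unreadable from compound 1 to compound 2. Compound 1 therefore stands at the weak end of a set that is weak throughout, and the limit of > 25000 nM in this assay, at which 2 of the 3 values shown sit, marks the ceiling at which it sits.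

Compound 4 `COc1cccc(/C=C/C(=O)c2sc(Nc3cccc(Cl)c3)nc2C)c1` differs from compound 1 in the other ring, the one carried on the amino group: chloro in place of methyl on an aromatic carbon. Among the compounds with values here, no measured step touches this part of the shared core, so none of the three steps bears directly on the change; the only guidance is that compound 1 itself gives a limit and that the one variation with a readable number moved the value only slightly.

The step that the limit leaves unreadable from compound 1 to compound 4 is therefore expected to be none beyond the scatter. Compound 4 is estimated at 30000 nM, within a range of 12000 nM to 80000 nM, most likely reported again as a limit.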

Compound 4, half-maximal inhibitory concentration: > 25000 nM
Compound 4: no number, only a limit; the forecaster's own chance of this, stated with the estimate: 70%; the middle value is on the limit's open side.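

Compound 4 gives > 25000 nM in this assay, which is a limit of the assay and not a number. Compound 1 also reaches only a limit, so no step can be read between compound 1 and compound 4. The compounds shown leave open how 3-chlorophenyl and 3-methylphenyl on the amino group compare, as most values sit at one ceiling: the limit of > 25000 nM in this assay, at which 3 of the 4 values shown sit.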